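The compounds below may be only part of what the source reports. "The series", "measured", "known", "first", "only" and "open" are said of these compounds alone.

Measured so far:
compound 1, `C=C1CC[C@H]2[C@@](C)(CC[C@@H](OC(=O)c3ccccc3)[C@@]2(C)NC=O)[C@@H]1/C=C/C1=CCOC1=O`: > 50000 nM
compound 2, `C=C1CC[C@H]2[C@@](C)(CC[C@@H](OC(=O)CN)[C@@]2(C)NC=O)[C@@H]1/C=C/C1=CCOC1=O`: > 50000 nM

Working notes. In an assay for inhibition of hexokinase-2 (Homo sapiens), read by coupled enzyme assay, with a stated time of 10 min, in the presence of a further agent that is not named here (a higher number here means a weaker inhibitor, a lower number a stronger inhibitor), compound 2 gives > 50000 nM, which is a limit of the assay and not a number. In this assay compound 1 gives > 50000 nM, likewise a limit and not a number. Because both values sit at the limit of > 50000 nM in this assay, at which 2 of the 2 values shown sit, the step that the two limits leave unreadable from compound 1 to compound 2 cannot be read in either direction or size; the exchange of aminomethyl for phenyl on the carbonyl carbon leaves no readable trace.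

Compound 3, `C=C1CC[C@H]2[C@@](C)(CC[C@@H](OC(=O)CNC)[C@@]2(C)NC=O)[C@@H]1/C=C/C1=CCOC1=O`, differs from compound 2 by methyl in place of hydrogen on an amine nitrogen. For the measured compounds named here, the only measured step concerns a different place and is itself unreadable, so no measured step gives a size or direction for this change in this assay. With both known compounds resting at the limit, compound 3 is expected to remain at that limit as well, the step that the limit leaves unreadable from compound 2 to compound 3 being an expectation of no readable change. The estimate for compound 3 in this assay is therefore 100000 nM, within 30000 nM to 400000 nM, most probably reported again only as a limit.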

Compound 3, half-maximal inhibitory concentration: > 50000 nM
Compound 3 was reported as a limit; the forecaster's own chance of this, stated with the estimate: 85%; the middle value lies beyond the limit too.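

In this assay compound 3 gives > 50000 nM as a limit of the assay and not a number. For the compounds shown here, no step among compound 1, compound 2 and compound 3 can be read, because all three rest at the same limit: the limit of > 50000 nM in this assay, at which 3 of the 3 values shown sit. The compounds shown leave open the size and direction of the exchanges on the carbonyl carbon and on the amine nitrogen.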